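Trimethoxyphenyl chalcone series: adding a third methoxy

The source may report more compounds than this note shows. Statements on the series, on what has been measured and on what is new or still open speak of the compounds shown alone.

Measured so far:
compound 1 `COc1ccc(C(=O)/C=C/c2cc(-c3cc(OC)c(OC)c(OC)c3)n[nH]2)cc1OC` — 78%
compound 2 `COc1ccc(C(=O)/C=C/c2cc(-c3cc(OC)c(OC)c(OC)c3)n[nH]2)cc1` — 84%

In a functional assay on A498 cells (Homo sapiens) for cytotoxicity, read by sulforhodamine B assay, with a stated time of 48 h, tested at 1 uM (a lower number here means a stronger effect, a higher number a weaker effect of the compound at the concentration tested), compound 1 gives 78%; compound 2 gives 84% in this assay. Compound 1 stands with compound 2 within the scatter: the step of a number 6 percentage points higher from compound 1 to compound 2 (within the scatter), brought about by hydrogen in place of methoxy on an aromatic carbon, does not rise above the usual spread of repeats.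

Compound 3 `COc1cc(C(=O)/C=C/c2cc(-c3cc(OC)c(OC)c(OC)c3)n[nH]2)cc(OC)c1OC` has not been measured. Against compound 1 it differs by methoxy in place of hydrogen on an aromatic carbon.

Within the data shown here, the only measured step that bears on this change is the one from compound 1 to compound 2, which runs the opposite way (removing a methoxy) and was a number 6 percentage points higher from compound 1 to compound 2 (within the scatter), within the scatter. Adding a methoxy on the same ring of compound 1 therefore has no measured step of its own, and the nearest comparison gives no reason to expect a shift beyond the scatter in this assay in either direction.

For compound 3 the expected step is a number 2 percentage points higher from compound 1 to compound 3 (within the scatter), and the estimated value is 80%, with a range from 64% to 93%.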

Compound 3, a percentage reported as activity, at one concentration (the size of the read-out at that concentration, not a potency): 80%
Estimate against measurement, compound 3: no gap at the digits printed; low and high end bracket the measured number.
By their numbers in this assay, from the lowest: compounds 1, 3 and 2 (each within the scatter of the next).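

In this assay, among these compounds, the step is a number 2 percentage points higher from compound 1 to compound 3 (within the scatter), the first direct reading of methoxy in place of hydrogen on this ring: a carbon ortho to a methoxy group and meta to a large group takes the added methoxy without a step beyond the scatter. Read beside a number 6 percentage points higher from compound 1 to compound 2 (within the scatter), removing a methoxy and adding one on this ring of compound 1 both stay within the scatter, so across these three compounds the number of methoxy groups on this ring shows no measurable link to the read-out at the single concentration tested. No measurement on hand accounts for this flat result, and the data give no basis for assigning any property to the added methoxy.

Still open, from the compounds shown here alone, is whether a group other than methoxy on this aromatic carbon, such as an amine, a carboxylic acid or a longer alkoxy chain, would give a step beyond the scatter. A single-concentration read-out also leaves open whether compound 1 and compound 3 would still sit within the scatter of each other at other concentrations.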